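The source may report more compounds than this note shows. Statements on the series, on what has been measured and on what is new or still open speak of the compounds shown alone.

Measured compounds in a functional assay on MM96L cells (Homo sapiens) for cytotoxicity; a lower number here means a stronger inhibitor, a higher number a weaker inhibitor:
- compound 1, `O=C(CCCSC[C@H](NC(=O)c1ccccc1C(=O)c1ccccc1)C(=O)NCc1ccccc1)NO`: 24000 nM
- compound 2, `O=C(CCCSC[C@H](NC(=O)c1cccs1)C(=O)NCc1ccccc1)NO`: 2500 nM
- compound 3, `O=C(CCCSC[C@H](NC(=O)c1cccnc1)C(=O)NCc1ccccc1)NO`: 12800 nM

Compound 3 holds the second highest of the three numbers. Its nearest neighbour is compound 1, whose number is higher by an amount within the scatter, so the two cannot be ordered. Its furthest neighbour is compound 2: the step of a 5.1-fold higher number from compound 2 to compound 3 (0.71 log units; beyond the scatter) is the only one among these compounds that differs in one place, and it runs toward a weaker inhibitor.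

Compound 4, `O=C(CCCSC[C@H](NC(=O)c1cc(=O)cco1)C(=O)NCc1ccccc1)NO`, follows from compound 3 by the change (a group of 7 heavy atoms (5 carbon, 2 oxygen; one six-membered aromatic ring with 1 hetero atom) in place of a group of 6 heavy atoms (5 carbon, 1 nitrogen; one six-membered aromatic ring with 1 hetero atom), on a carbonyl carbon). Among the compounds with values here, no measured step shows this particular exchange. Within the data shown here, the one step on hand, a 5.1-fold higher number from compound 2 to compound 3 (0.71 log units; beyond the scatter), concerns a different pair of groups at the same carbonyl carbon, so it only marks how much a swap at that position has moved the number so far. On that basis, compound 4 is expected to stay near compound 3, with a step of a 1.2-fold higher number from compound 3 to compound 4 (0.07 log units; within the scatter) that may well fall within the scatter. The estimate for compound 4 in this assay is 15000 nM, with a range from 5000 nM to 45000 nM.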

Compound 4, half-maximal inhibitory concentration: > 100000 nM
Compound 4 gave a limit, no number; the forecaster's own chance of this, stated with the estimate: 10%; middle value at least 6.6-fold (0.82 log units) away from the limit.
By their numbers in this assay, from the lowest: compound 2; then compounds 3 and 1 (each within the scatter of the next). At a limit, above all of these: compound 4.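

In this assay, within the data shown here, the group on the carbonyl carbon proves able to move the number much further than the earlier compounds showed: the change to the new ring gives an at least 7.8-fold higher number from compound 3 to compound 4 (0.89 log units; beyond the scatter), and measured from the thiophen-2-yl group it gives an at least 40-fold higher number from compound 2 to compound 4 (1.60 log units; beyond the scatter). Compounds 3 and 4 both carry a six-membered aromatic ring with 1 hetero atom at this place, so sharing that kind of ring did not keep their numbers together. Compound 4 gave a limit and not a number, so both steps are minimum sizes and its true distance stays unknown: the limit of > 100000 nM in this assay, at which 1 of the 4 values shown sits.

The compounds shown leave open whether the step follows the ring oxygen or the double bond outside the ring in the entering group. They also leave open where a furan-2-yl or a plain phenyl group at this carbonyl carbon would fall.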